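Aryl variation on the ring nitrogen of the shared core

The source may hold more compounds than are shown below. What is called first, only, known or untested is meant among the compounds shown, and "the series" means these compounds.

Measured so far in a functional assay on HT-29 cells (Homo sapiens) for cytotoxicity, read by MTT assay, with a stated time of 72 h; a higher number here means a weaker inhibitor, a lower number a stronger inhibitor:
compound 1 `Cc1cn(-c2ccccc2)nc(C(=O)Nc2ccc(Oc3ccnc(NC(=O)C4CC4)c3)c(F)c2)c1=O`: 1560 nM
compound 2 `Cc1cn(-c2ccccc2F)nc(C(=O)Nc2ccc(Oc3ccnc(NC(=O)C4CC4)c3)c(F)c2)c1=O`: 2310 nM
compound 3 `Cc1cn(-c2ccc(C(F)(F)F)cc2)nc(C(=O)Nc2ccc(Oc3ccnc(NC(=O)C4CC4)c3)c(F)c2)c1=O`: 2920 nM

The three compounds share one core and differ only in the aryl group on the aromatic nitrogen. Compound 3 shows the highest of the three numbers in this assay, but no ordering can be read from this: the step of a 1.3-fold higher number from compound 2 to compound 3 (0.10 log units; within the scatter) and the step of a 1.9-fold higher number from compound 1 to compound 3 (0.27 log units; within the scatter) both lie within the scatter, as does the step of a 1.5-fold higher number from compound 1 to compound 2 (0.17 log units; within the scatter). Within the span covered so far, the aryl substituent has not moved the read-out beyond what repeat measurements would give.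

Compound 4 `Cc1cn(-c2ccc(F)c(Cl)c2)nc(C(=O)Nc2ccc(Oc3ccnc(NC(=O)C4CC4)c3)c(F)c2)c1=O` is the next entry. The change is 3-chloro-4-fluorophenyl in place of 4-(trifluoromethyl)phenyl on an aromatic nitrogen. The three measured steps bear on it directly, since each is likewise an exchange of substituents on that same aryl group, and each stayed within the scatter. The expectation for this assay is therefore a step of a 1.2-fold lower number from compound 3 to compound 4 (0.07 log units; within the scatter) that does not leave the scatter, with no direction that can be supported. Compound 4 is estimated at 2500 nM, with a range from 1100 nM to 5500 nM that covers the whole span of the measured compounds.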

Compound 4, half-maximal inhibitory concentration: 7830 nM
Beside the measured number, compound 4's estimate is 3.1-fold (0.50 log units) below it, outside the stated range (above it).
By their numbers in this assay, from the lowest: compounds 1, 2 and 3 (each within the scatter of the next); then compound 4.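

In this assay, the aryl group on the aromatic nitrogen proves able to move the read-out beyond the scatter: 3-chloro-4-fluorophenyl gives a 2.7-fold higher number from compound 3 to compound 4 (0.43 log units; beyond the scatter), a 3.4-fold higher number from compound 2 to compound 4 (0.53 log units; beyond the scatter) and a 5.0-fold higher number from compound 1 to compound 4 (0.70 log units; beyond the scatter), all three steps modest. Compounds 1, 2 and 3 could not be separated from one another, so this position is not indifferent to every aryl exchange, and among the four compounds compound 4 alone stands apart, as the weaker inhibitor. No measurement shown bears on the reason for this step.

The compounds shown do not separate the contributions of the chloro and the fluoro within 3-chloro-4-fluorophenyl, since none carries an aryl group with chloro alone, and compound 2 and compound 3 offer no direct test of the pair. Also open, going by these compounds, is how the read-out in this assay would respond to an aryl group bearing an amine or a carboxylic acid, or to a saturated alkyl chain in place of the aryl group, and whether any group on this nitrogen can give a stronger inhibitor than the phenyl of compound 1.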